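Swapping the aryl group on a cytotoxic stilbene-like series

The compounds below may be only part of what the source reports. "The series", "measured", "known", "first", "only" and "open" are said of these compounds alone.

Measured in a functional assay on DU-145 cells (Homo sapiens) for cytotoxicity, read by MTT assay, with a stated time of 48 h; on this read-out higher numbers stand for weaker inhibition and lower numbers for stronger inhibition:
- compound 1 `COc1ccc(/C=C/c2cc(OC)c(OC)c(OC)c2-c2ccc(F)c(F)c2)cc1`: 7500 nM
- compound 2 `COc1ccc(/C=C/c2cc(OC)c(OC)c(OC)c2-c2ccc3ccccc3c2)cc1`: 32000 nM
- compound 3 `COc1ccc(/C=C/c2cc(OC)c(OC)c(OC)c2-c2ccc(Cl)cc2)cc1`: 35000 nM

Compound 3 gives 35000 nM, which places it at the weak end of these three numbers. The measured step there is a 1.1-fold higher number from compound 2 to compound 3 (0.04 log units; within the scatter), so the naphthalen-2-yl and 4-chlorophenyl groups cannot be told apart.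

Compound 4 `COc1ccc(/C=C/c2cc(OC)c(OC)c(OC)c2-c2ccc(OC)c(OC)c2)cc1` carries 3,4-dimethoxyphenyl in place of 4-chlorophenyl on an aromatic carbon. Among the compounds with values here, no measured compound has a methoxy group on this ring, so the evidence is indirect. Only compound 1 stands apart, at 7500 nM. The two modest steps that set it apart are a 4.3-fold higher number from compound 1 to compound 2 (0.63 log units; beyond the scatter) and a 4.7-fold higher number from compound 1 to compound 3 (0.67 log units; beyond the scatter). Its 3,4-difluorophenyl group is the closest measured match to the entering group, which suggests a small move toward lower numbers in this assay, though none clearly beyond the scatter. The estimated change is a 1.8-fold lower number from compound 3 to compound 4 (0.24 log units; within the scatter). Compound 4 is expected at 20000 nM, with an estimated range of 7000 nM to 50000 nM.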

Compound 4, half-maximal inhibitory concentration: 34000 nM
Estimate against measurement, compound 4: 1.7-fold (0.23 log units) below, and the stated range covers the measured number.
By their numbers in this assay, from the lowest: compound 1; then compounds 2, 4 and 3 (each within the scatter of the next).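

In this assay the step of a 1.0-fold lower number from compound 3 to compound 4 (0.01 log units; within the scatter) and the step of a 1.1-fold higher number from compound 2 to compound 4 (0.03 log units; within the scatter) place the 3,4-dimethoxyphenyl group alongside the 4-chlorophenyl and naphthalen-2-yl groups, so these three aryl groups at this position cannot be told apart. The 3,4-dimethoxyphenyl and 3,4-difluorophenyl groups carry their substituents at the same ring positions, yet the step of a 4.5-fold higher number from compound 1 to compound 4 (0.66 log units; beyond the scatter) separates them, so that substitution pattern alone does not go with the lower number, and compound 1 remains the only one that stands apart. No measurement at hand explains why the 3,4-difluorophenyl group differs from the other three.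

On these data alone, whether a ring with a single fluorine would keep the lower number of compound 1 stays open. So does what an amine or a carboxylic acid on this ring would do.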